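The source may report more compounds than this note shows. Statements on the series, on what has been measured and on what is new or still open speak of the compounds shown alone.

Measured compounds:
- Compound 1, `COc1ccc(/C=C2\CCC/C(=C\c3cccc(OC)c3OC)C2=O)cc1`: in a functional assay on A549 cells (Homo sapiens) for cytotoxicity, read by MTT assay, with a stated time of 72 h (a lower number here means a stronger inhibitor, a higher number a weaker inhibitor), it is reported only as the limit > 20000 nM.
- Compound 2, `COc1ccc(/C=C2\CCC/C(=C\c3cccc(OC)c3OC)C2=O)cc1OC`: in this assay compound 2 gives 14400 nM.

Compound 2 therefore holds the only actual number shown in this assay; the other entry is a limit, (the limit of > 20000 nM in this assay, at which 1 of the 2 values shown sits). The step of an at least 1.3-fold lower number from compound 1 to compound 2 (0.14 log units; that floor lies within the scatter) is a methoxy in place of hydrogen on an aromatic carbon, and its floor lies within the usual scatter, so it gives no clear direction.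

Compound 3, `COc1ccccc1/C=C1\CCC/C(=C\c2ccc(OC)c(OC)c2)C1=O`, has not been measured in this assay. Its change from compound 2 is hydrogen in place of methoxy on an aromatic carbon. Among the compounds with values here, the only measured step that bears on it is the methoxy exchange an at least 1.3-fold lower number from compound 1 to compound 2 (0.14 log units; that floor lies within the scatter) on the other aromatic ring, which stayed within the scatter. On that evidence no step beyond the scatter is expected for compound 3, and its number may again come back only as a limit. The expected step is a 1.4-fold higher number from compound 2 to compound 3 (0.14 log units; within the scatter), and compound 3 is estimated at 20000 nM, with a range from 8000 nM to 50000 nM.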

Compound 3, half-maximal inhibitory concentration: > 20000 nM
Compound 3 was reported as a limit; the forecaster's own chance of this, stated with the estimate: 40%; the middle value lies on the limit itself.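

In this assay compound 3 is reported only as a limit, > 20000 nM. The step of an at least 1.3-fold higher number from compound 2 to compound 3 (0.14 log units; that floor lies within the scatter) is hydrogen in place of methoxy on an aromatic carbon, ortho to a methoxy group and meta to a large group, so this position on the second aromatic ring gives no clear direction either. Until now only the other aromatic ring had been changed; compound 2 remains the only compound with an actual number, and the loss of a methoxy group from either ring returns a limit: the limit of > 20000 nM in this assay, at which 2 of the 3 values shown sit.

As far as these compounds go, with two of the three readings given as limits, the true size of both steps remains unknown, and neither methoxy group can be said to matter on this evidence. Also open, from the compounds shown here alone, is whether another group on this aromatic carbon, such as a hydroxy group, an amine or a carboxylic acid, would give a number clearly lower than that of compound 2, 14400 nM.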